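Bromo for tert-butyl on the benzoxazole-free shared core

The source may report more compounds than this note shows. Statements on the series, on what has been measured and on what is new or still open speak of the compounds shown alone.

Measured so far:
compound 1, `CN1CCN(c2nc3cccc(Cl)c3o2)CC1`: 5.5
compound 2, `CN1CCN(c2nc3cc(C(C)(C)C)ccc3o2)CC1`: < 4

In a functional assay on ileum (strain Hartley) for agonist activity at 5-hydroxytryptamine receptor 3A (Cavia porcellus) (a higher number here means a more potent compound, by a factor of ten per unit of this negative logarithm, a lower number a less potent compound), compound 1 gives 5.5. Compound 2 gives only a limit of the assay, < 4, not a number; it sits at the limit of < 4 in this assay, at which 1 of the 2 values shown sits. Compound 3, `CN1CCN(c2nc3cc(Br)ccc3o2)CC1`, is not yet measured. The change is bromo in place of tert-butyl on an aromatic carbon. For the measured compounds named here, no step between two measured compounds is available, so the size of the effect rests on expectation alone. The step from the limit is expected to be a number at least 0.70 log units higher from compound 2 to compound 3 (beyond the scatter), upward, likely beyond the scatter. Compound 3 is expected to give about 4.7, between 4 and 5.5.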

Compound 3, negative logarithm of the half-maximal effective concentration: 6.21
Estimate against measurement, compound 3: 1.51 log units below; measured number above the stated range.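

In this assay, an aromatic carbon that carries tert-butyl in a compound at the limit can also carry a substituent that gives a full number: bromo in place of tert-butyl gives a number at least 2.21 log units higher from compound 2 to compound 3 (beyond the scatter). Compound 2 gives < 4, a limit of the assay and not a number. The full size of the step stays unknown because one end of it is a limit: the limit of < 4 in this assay, at which 1 of the 3 values shown sits.

Going by these compounds, whether the gain belongs to bromo itself or to the loss of tert-butyl stays open. So does how a methoxy group, an amine or a carboxylic acid on this carbon would read in this assay.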